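Dropping the piperazine from a biphenyl amide antagonist

The source may report more compounds than this note shows. Statements on the series, on what has been measured and on what is new or still open speak of the compounds shown alone.

Measured compounds:
- compound 1, `Clc1cncc(Cl)c1N/N=C/c1ccccc1-c1ccccc1Br`, 49 nM
- compound 2, `Cc1ccccc1-c1cc(N2CCN(C)CC2)ccc1C(=O)N(C)Cc1cc(C(F)(F)F)cc(C(F)(F)F)c1`, 1.4 nM
- compound 3, `Cc1ccccc1-c1cnc(N2CCN(C)CC2)cc1N(C)C(=O)C(C)(C)c1cc(C(F)(F)F)cc(C(F)(F)F)c1`, 1.7 nM

All three were examined in an assay on CHO cells for displacement of a labelled ligand from Substance-P receptor (Homo sapiens); on this read-out lower numbers stand for stronger inhibition and higher numbers for weaker inhibition. Compound 2 shows the lowest of the three numbers. Compound 3 sits so close to it that the two values fall within the usual scatter, so no order between them can be claimed. Compound 1, on a different core, gives a number far beyond the scatter of compound 2.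

The unmeasured compound 4, `Cc1ccccc1-c1ccccc1C(=O)N(C)Cc1cc(C(F)(F)F)cc(C(F)(F)F)c1`, is derived from compound 2 by a single change: hydrogen in place of 4-methylpiperazin-1-yl on an aromatic carbon. Among the measured compounds shown here, no measured pair in this set shows that change, so its effect in this assay must be estimated rather than read off. The 4-methylpiperazin-1-yl group is a sizeable part of compound 2, and its removal leaves the remainder of the molecule intact. A modest weakening is expected, as in a 3.6-fold higher number from compound 2 to compound 4 (0.55 log units; beyond the scatter). On that basis compound 4 is estimated to give 5 nM in this assay, within a range from 1.5 nM to 20 nM.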

Compound 4, inhibition constant: 17 nM
For compound 4 the middle estimate is 3.4-fold (0.53 log units) below the measured one; measured number inside the range.
By their numbers in this assay, from the lowest: compounds 2 and 3 (each within the scatter of the next); then compound 4; then compound 1.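

In this assay, among the compounds shown here, hydrogen in place of 4-methylpiperazin-1-yl on an aromatic carbon gives a 12-fold higher number from compound 2 to compound 4 (1.08 log units; beyond the scatter), a large step and the first reading of a single change in this set. It shows that this position, meta to a 2-methylphenyl group and para to a large group, is not indifferent to what it carries, although compound 4 keeps a measurable number of 17 nM without the ring. Nothing measured here accounts for the size of this step.

On these data alone, it remains open whether a smaller amine such as dimethylamino, a morpholine ring or a carboxylic acid at this position would give a number closer to compound 2 or to compound 4. Also open, as far as these compounds go, is whether taking 4-methylpiperazin-1-yl off compound 3 would cost as much.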